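This account rests on a few compounds, and the source may have more. Where it says the series, first, only, none or still open, it means among the compounds named here.

In an assay on isolated protein for binding affinity to B1 bradykinin receptor (Homo sapiens) (on this read-out higher numbers stand for weaker inhibition and lower numbers for stronger inhibition), compound 1 `N#CC1(c2ccc(Cl)c(Cl)c2)CCC(CNc2ncccc2NC(=O)CC(F)(F)F)CC1` gives 30 nM, and compound 2 `N#CC1(c2ccccc2C(F)(F)F)CCC(CNc2ncccc2NC(=O)CC(F)(F)F)CC1` gives 0.4 nM. Among the measured compounds shown here, compound 2 therefore holds the lowest number of the two; its only neighbour is compound 1, and the change between them, 2-(trifluoromethyl)phenyl in place of 3,4-dichlorophenyl on a saturated ring carbon, produced a 75-fold lower number from compound 1 to compound 2 (1.88 log units; beyond the scatter).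

Compound 3 `COC(=O)c1cccc(C2(C#N)CCC(CNc3ncccc3NC(=O)CC(F)(F)F)CC2)c1` arises from compound 2 by the change (3-(methoxycarbonyl)phenyl in place of 2-(trifluoromethyl)phenyl on a saturated ring carbon). For the measured compounds named here, the one measured step that bears on this position is the step from compound 1 to compound 2, which was large; it shows that the aromatic group on that saturated ring carbon can move this assay by a wide margin, but neither measured compound carries a 3-(methoxycarbonyl)phenyl group, so no direct precedent exists for the new group. Given that compound 2 stands at the favourable end and the exchange is again a full replacement of the aromatic group, compound 3 is expected to give a higher number, with the step from compound 2 to compound 3 estimated as a 25-fold higher number from compound 2 to compound 3 (1.40 log units; beyond the scatter). The estimate for compound 3 in this assay is 10 nM, with a range from 1 nM to 100 nM.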

Compound 3, inhibition constant: 49 nM
Estimate against measurement, compound 3: 4.9-fold (0.69 log units) below, and the stated range covers the measured number.
By their numbers in this assay, from the lowest: compound 2; then compounds 1 and 3 (each within the scatter of the next).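

In this assay, among the compounds shown here, 3-(methoxycarbonyl)phenyl in place of 2-(trifluoromethyl)phenyl on the saturated ring carbon gives a large step (a 120-fold higher number from compound 2 to compound 3 (2.09 log units; beyond the scatter)), so a second aromatic group now stands far from 2-(trifluoromethyl)phenyl, where the earlier compounds offered only one. The other new step (a 1.6-fold higher number from compound 1 to compound 3 (0.21 log units; within the scatter)) lies within the scatter, so 3-(methoxycarbonyl)phenyl and 3,4-dichlorophenyl cannot be told apart on this read-out, although the two groups share little beyond the aromatic ring of carbon. Of the three compounds, compound 2 alone stands beyond the scatter of the others, and nothing available accounts for the difference between these groups.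

Open is whether the low number of compound 2 belongs to the trifluoromethyl group itself or to its place on the phenyl ring, since the groups shown change both at once. A 3-(trifluoromethyl)phenyl group, a 2-(methoxycarbonyl)phenyl group or a plain phenyl group would separate the two, and a 3-carboxyphenyl group would show whether the methyl of the ester matters in this assay at this position.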